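Series notes: methoxy in place of chloro, compound 2 to compound 4

The compounds below may be only part of what the source reports. "The series", "measured", "known", "first", "only" and "open" are said of these compounds alone.

Three compounds have numbers in an assay on mitochondria for inhibition of Amine oxidase [flavin-containing] A (Bos taurus); a lower number here means a stronger inhibitor, a higher number a weaker inhibitor. Compound 1 `Cc1csc(N/N=C/c2ccc(Cl)cc2)n1` gives 38 nM, compound 2 `Clc1ccc(/C=N/Nc2nc(-c3ccccc3)cs2)cc1` gives 100 nM, and compound 3 `Clc1ccc(/C=N/Nc2nc(-c3ccccc3)cs2)c(Cl)c1` gives 93.3 nM. Compound 2 holds the highest number of the three: nearest is compound 3, a 1.1-fold lower number from compound 2 to compound 3 (0.03 log units; within the scatter), within the scatter; furthest is compound 1, a 2.6-fold higher number from compound 1 to compound 2 (0.42 log units; beyond the scatter), beyond the scatter. Compound 4 `COc1ccc(/C=N/Nc2nc(-c3ccccc3)cs2)cc1` differs from compound 2 by methoxy in place of chloro on an aromatic carbon, on an aromatic carbon of a six-membered aromatic ring of carbon only, para to a large group. Among the compounds with values here, no measured step swaps one substituent for another in this way. The step of a 1.1-fold lower number from compound 2 to compound 3 (0.03 log units; within the scatter) also alters a chloro on an aromatic carbon and stays within the scatter, while a 2.6-fold higher number from compound 1 to compound 2 (0.42 log units; beyond the scatter) exchanges phenyl for methyl and is a different kind of change. A step of at most modest size is therefore expected in this assay, with no clear direction. Compound 4 is estimated at 150 nM, with a range from 50 nM to 450 nM, which means an expected 1.5-fold higher number from compound 2 to compound 4 (0.18 log units; within the scatter).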

Compound 4, inhibition constant: 50.1 nM
Beside the measured number, compound 4's estimate is 3.0-fold (0.48 log units) above it, and the stated range covers the measured number.
By their numbers in this assay, from the lowest: compounds 1, 4, 3 and 2 (each within the scatter of the next, the first and the last beyond it).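

In this assay, within the data shown here, this is the first swap of one substituent for another at the place para to a large group: methoxy in place of chloro gives a 2.0-fold lower number from compound 2 to compound 4 (0.30 log units; within the scatter) and so stays within the scatter, even though methoxy brings two heavy atoms and one hydrogen-bond acceptor where chloro had one heavy atom and none. Alongside a 1.1-fold lower number from compound 2 to compound 3 (0.03 log units; within the scatter), a second change on this ring now leaves the number within the scatter, whereas the only step beyond it, a 2.6-fold higher number from compound 1 to compound 2 (0.42 log units; beyond the scatter), lies on the other side of the shared core. Nothing available bears on why the exchange has so little effect here.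

The compounds shown carry only chloro and methoxy at this place, so an amine, a carboxylic acid or a longer chain such as butoxy remains open. Also open, as far as these compounds go, is whether methoxy in place of chloro reads the same on the core of compound 1, which carries methyl rather than phenyl.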